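This account rests on a few compounds, and the source may have more. Where it says the series, first, only, none or still open, it means among the compounds named here.

Compounds measured so far:

compound 1, `CCCCc1cnc(CCCc2ccc(-c3ccccc3C(=O)O)cc2)[nH]1`, 5600 nM
compound 2, `O=C(O)c1ccccc1-c1ccc(CCc2ncc(CC3CCOCC3)[nH]2)cc1`, 338 nM
compound 3, `CCC(C)(C)Cc1c[nH]c(CCc2ccc(-c3ccccc3C(=O)O)cc2)n1`, 25 nM

All three were tested in an in vitro functional assay on cells for agonist activity at Bombesin receptor subtype-3 (Homo sapiens), read by luminescence and calcium flux; on this read-out higher numbers stand for an effect only at larger amounts of compound and lower numbers for an effect already at smaller amounts. Compound 2 stands second highest of the three: compound 3 sits far lower, beyond the scatter, and compound 1 far higher, also beyond the scatter. Compound 4, `O=C(O)c1ccccc1-c1ccc(CCc2ncc(Cc3ccc(Cl)cc3)[nH]2)cc1`, has not yet been measured. It differs from compound 2 by 4-chlorophenyl in place of oxan-4-yl on a saturated chain carbon bound to an aromatic carbon. Among the measured compounds shown here, no measured pair shows this exact change, so the expected size of the step rests on the neighbours only: compound 3 gives 25 nM with a branched saturated group at the same position, which suggests that a different group there can lower the number well beyond the scatter. Compound 4 is therefore expected to land at 110 nM, between 25 nM and 500 nM, an estimated step of a 3.1-fold lower number from compound 2 to compound 4 (0.49 log units; beyond the scatter).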

Compound 4, half-maximal effective concentration: 2290 nM
For compound 4 the middle estimate is 21-fold (1.32 log units) below the measured one; measured number outside the range, above it.
By their numbers in this assay, from the lowest: compound 3; then compound 2; then compound 4; then compound 1.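

In this assay, among the compounds shown here, placing 4-chlorophenyl instead of oxan-4-yl on the saturated chain carbon gives a 6.8-fold higher number from compound 2 to compound 4 (0.83 log units; beyond the scatter) and so provides the first single-change reading at this position. It shows that the ring carried there affects the result, even though the two groups are similar in size. Nothing available explains the rise. As far as these compounds go, it remains open whether the rise comes from the aromatic ring itself or from its chlorine. A plain phenyl group at this position would separate the two.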